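This account rests on a few compounds, and the source may have more. Where it says the series, first, only, none or still open, it means among the compounds named here.

Compound 1 `O=C(CCc1nc2ccccc2c(=O)[nH]1)N/N=C/c1ccc(O)c(O)c1`: 255000000 nM
Compound 2 `COc1cc(/C=N/NC(=O)CCCc2nc3ccccc3c(=O)[nH]2)cc(OC)c1OC`: 613000000 nM

In a functional assay on cells (Erythrocyte, Homo sapiens) for inhibition, read by spectrophotometry and hemolysis, with a stated time of 10 min (on this read-out lower numbers stand for stronger inhibition and higher numbers for weaker inhibition), compound 2 gives 613000000 nM, the higher of the two numbers and so the weaker inhibition, and the gap to compound 1 lies beyond the scatter. Compound 3 `COc1cc(/C=N/NC(=O)CCCc2nc3ccccc3c(=O)[nH]2)cc(OC)c1O` is compound 2 with hydrogen in place of methyl on an oxygen on an aromatic ring, methoxy to hydroxy: hydrogen in place of methyl on an oxygen on an aromatic ring. Among the measured compounds shown here, no measured pair shows this change alone. Compound 1, which has hydroxy groups but also differs elsewhere, gives 255000000 nM, so a modest move toward lower numbers is expected, perhaps not beyond the scatter. The estimated change is a 1.8-fold lower number from compound 2 to compound 3 (0.24 log units; within the scatter). For compound 3 the estimate is 350000000 nM, with an expected range from 150000000 nM to 700000000 nM.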

Compound 3, half-maximal inhibitory concentration in the Erythrocyte assay: 524000000 nM
Beside the measured number, compound 3's estimate is 1.5-fold (0.18 log units) below it, and the stated range covers the measured number.
By their numbers in the Erythrocyte assay, from the lowest: compound 1; then compounds 3 and 2 (each within the scatter of the next).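

Methoxy to hydroxy on this oxygen can now be read on its own. In the Erythrocyte assay compound 2 gives 613000000 nM and compound 3 gives 524000000 nM. In the Erythrocyte assay the change is a 1.2-fold lower number from compound 2 to compound 3 (0.07 log units; within the scatter), so this read-out does not separate the two compounds. In a physicochemical assay, read by spectrophotometry, with a stated time of 15 min (a higher number here means a weaker inhibitor, a lower number a stronger inhibitor), compound 2 gives 85000000 nM and compound 3 gives 225000000 nM. The same change in the physicochemical assay gives a 2.6-fold higher number from compound 2 to compound 3 (0.42 log units; beyond the scatter), making compound 3 the weaker inhibitor there. A single swap at this position therefore matters in one read-out and not in the other.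

Going by these compounds, it remains open whether an amine or a carboxylic acid in place of the hydroxy would change either read-out, and whether this split between read-outs holds on other compounds.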